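Dropping the Dimethylcarbamoyl Group: A Small Loss Expected

The source may report more compounds than this note shows. Statements on the series, on what has been measured and on what is new or still open speak of the compounds shown alone.

Of the compounds shown here, two have so far been tested in an assay on isolated protein for inhibition of serine/threonine-protein kinase Sgk1 (Homo sapiens), tested at 1 uM; a higher number here means more inhibition at the concentration tested (going by the name of the read-out), a lower number less inhibition. Compound 1, `CN(C)C(=O)c1ccc2c(c1)/C(=C(/Nc1ccc(CN3CCCCC3)cc1)c1ccccc1)C(=O)N2`, gives 68% in this assay. Compound 2, `CCNC(=O)c1ccc2c(c1)NC(=O)/C2=C(\Nc1ccc(CN(C)C)cc1)c1ccccc1`, gives 124% in this assay. Compound 1 therefore stands lowest of the two numbers; compound 2 sits well above it, and the gap between them lies beyond the usual scatter of repeated measurements. Because the two structures differ in more than one place, that gap cannot be traced to a single change.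

Compound 3, `O=C1Nc2ccccc2/C1=C(/Nc1ccc(CN2CCCCC2)cc1)c1ccccc1`, has not yet been measured. It is compound 1 with one alteration: hydrogen in place of dimethylcarbamoyl on an aromatic carbon. The group that leaves sits on an aromatic carbon of a six-membered aromatic ring of carbon only, part of a fused system of two rings, and a hydrogen atom takes its place; nothing else in the molecule changes.

Within the data shown here, no measured pair isolates this change, so the expectation rests on compound 1 alone. The step of a number 16 percentage points lower from compound 1 to compound 3 (beyond the scatter) is expected to be a modest loss, not far beyond the scatter. Compound 3 is accordingly estimated at 52% in this assay, within a range from 22% to 82%.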

Compound 3, a percentage reported as inhibition, at one concentration (the size of the read-out at that concentration, not a potency): 20%
The estimate for compound 3 lay 32 percentage points above the measured number; the whole stated range lies above it.
By their numbers in this assay, from the lowest: compound 3; then compound 1; then compound 2.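

Hydrogen in place of dimethylcarbamoyl on this aromatic carbon gives, in this assay, a number 48 percentage points lower from compound 1 to compound 3 (beyond the scatter), which makes this the first single change in the series whose effect can be read on its own. The position, meta to a fused ring and para to a fused ring, is therefore not a neutral spot: with everything else in compound 1 held fixed, removing this one group takes away a large part of the inhibition seen at the tested concentration. Nothing at hand tells what lies behind this loss.

Open, on these data alone, is whether the dimethylcarbamoyl group itself matters or whether other groups on this carbon would hold the number up, a question that a simple methyl group, a carboxylic acid or a primary amine in the same place could help to settle. Also open, as far as these compounds go, is whether removing the group from this carbon would cost as much in a compound with a different side chain, since this one step comes from a single pair that carries the piperidine ring.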